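The compounds below may be only part of what the source reports. "The series", "measured", "known", "first", "only" and "open" are said of these compounds alone.

In a functional assay on HepG2 cells (Homo sapiens) for cytotoxicity, read by MTT assay, with a stated time of 24 h (on this read-out higher numbers stand for weaker inhibition and lower numbers for stronger inhibition), compound 1 (`CN1C/C(=C\c2cccnc2)C(=O)/C(=C/c2ccccc2F)C1`) gives 4810 nM and compound 3 (`CN1C/C(=C\c2ccc(C(F)(F)F)cc2)C(=O)/C(=C/c2cccnc2)C1`) gives 4790 nM, the two lying within the scatter of each other, whereas compound 2 (`CN1C/C(=C\c2cccnc2)C(=O)/C(=C/c2ccc(F)cc2Br)C1`) gives 13000 nM and stands apart from both. Compound 4 (`CN1C/C(=C\c2ccc(C#N)cc2)C(=O)/C(=C/c2cccnc2)C1`) differs from compound 3 by cyano in place of trifluoromethyl on an aromatic carbon. Among the measured compounds shown here, the one measured step (a 2.7-fold higher number from compound 1 to compound 2 (0.43 log units; beyond the scatter)) was modest and concerned other groups, so no measured step tests this exchange directly. No change beyond the scatter is therefore expected in this assay (a 1.0-fold higher number from compound 3 to compound 4 (0.02 log units; within the scatter)). Compound 4 is estimated at 5000 nM (expected range 2000 nM to 13000 nM).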

Compound 4, half-maximal inhibitory concentration: 12700 nM
The estimate for compound 4 lay 2.5-fold (0.40 log units) below the measured number; the range from low to high includes it.
By their numbers in this assay, from the lowest: compounds 3 and 1 (each within the scatter of the next); then compounds 4 and 2 (each within the scatter of the next).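

In this assay, cyano in place of trifluoromethyl on an aromatic carbon, para to a large group, gives a 2.7-fold higher number from compound 3 to compound 4 (0.42 log units; beyond the scatter) and so shows that this exchange is modest but not silent. The 4-cyanophenyl group also gives a 2.6-fold higher number from compound 1 to compound 4 (0.42 log units; beyond the scatter) when set against 2-fluorophenyl, while a 1.0-fold lower number from compound 2 to compound 4 (0.01 log units; within the scatter) places it level with 2-bromo-4-fluorophenyl. As far as these compounds go, whether an amine or a carboxylic acid on this aromatic carbon would read like trifluoromethyl or like cyano remains open. Nothing at hand bears on what lies behind these steps.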